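Replacing naphthalen-1-yl in compound 2: working notes

The compounds below may be only part of what the source reports. "The series", "measured", "known", "first", "only" and "open" are said of these compounds alone.

Compound 1 `COc1cc(/C=C/C(=O)/C=C/c2cccc3ccccc23)ccc1OCc1cn(CCOc2cc(=O)oc3ccccc23)nn1`: 83%
Compound 2 `COc1cc(/C=C/C(=O)/C=C/c2cccc3ccccc23)ccc1OCc1cn(CCCCCOc2cc(=O)oc3ccccc23)nn1`: 42%

In a functional assay on HCT-116 cells (Homo sapiens) for inhibition, read by sulforhodamine B assay, with a stated time of 48 h, tested at 50 uM (on this read-out higher numbers stand for more inhibition of growth at the one concentration tested and lower numbers for less inhibition of growth), compound 2 is the lower of the two, at 42%, and compound 1 stands at 83%. The gap between these two values lies beyond the scatter. Compound 3 `COc1ccccc1/C=C/C(=O)/C=C/c1ccc(OCc2cn(CCCCCOc3cc(=O)oc4ccccc34)nn2)c(OC)c1` is related to compound 2 by 2-methoxyphenyl in place of naphthalen-1-yl on a double-bonded chain carbon bound to a double-bonded chain carbon, with 2-methoxyphenyl in place of naphthalen-1-yl. Among the compounds with values here, no measured pair shows this exchange, so the size of its effect remains open. No change beyond the scatter is expected, and the estimated a number 3 percentage points higher from compound 2 to compound 3 (within the scatter) is small. In this assay compound 3 is expected at 45%, with an estimated range of 22% to 70%.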

Compound 3, percent growth inhibition at one concentration: 33%
Compound 3: the middle estimate sits 12 percentage points above what was measured, within the range that was stated.
By their numbers in this assay, from the lowest: compounds 3 and 2 (each within the scatter of the next); then compound 1.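

The step of a number 9 percentage points lower from compound 2 to compound 3 (within the scatter) in this assay shows that, on a double-bonded chain carbon bound to a double-bonded chain carbon, 2-methoxyphenyl can take the place of naphthalen-1-yl without a change beyond the scatter. With the chain of compound 2, going from two aromatic rings to one and adding one hydrogen-bond acceptor thus leaves the read-out within the scatter. No available data bear on the reason for this result. Open, going by these compounds, is how a phenyl group carrying an amine or a carboxylic acid would behave here. Also open, on these data alone, is whether the same exchange on compound 1, with its different chain, would stay within the scatter.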